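Loss of the amide hydrogen and a chlorine added together

The source may report more compounds than this note shows. Statements on the series, on what has been measured and on what is new or still open speak of the compounds shown alone.

Of the compounds shown here, three sharing one core have been measured in a functional assay on L6 cells (Rattus norvegicus) for inhibition; on this read-out higher numbers stand for weaker inhibition and lower numbers for stronger inhibition. Compound 1, `CC(C)c1c(C(=O)NCc2ccccc2)nn(-c2ccc(F)cc2)c1OC[C@@H](O)C[C@@H](O)CC(=O)O`, gives 880 nM, the lowest of the three numbers. Compound 2, `CC(C)c1c(C(=O)N2CCCCC2)nn(-c2ccc(F)cc2)c1OC[C@@H](O)C[C@@H](O)CC(=O)O`, gives 32200 nM, and compound 3, `CC(C)c1c(C(=O)NCc2ccccc2Cl)nn(-c2ccc(F)cc2)c1OC[C@@H](O)C[C@@H](O)CC(=O)O`, gives 8450 nM. The two measured steps away from compound 1 both run toward weaker inhibition: a 37-fold higher number from compound 1 to compound 2 (1.56 log units; beyond the scatter), and a 9.6-fold higher number from compound 1 to compound 3 (0.98 log units; beyond the scatter).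

Compound 4, `CC(C)c1c(C(=O)N(C)Cc2cccc(Cl)c2)nn(-c2ccc(F)cc2)c1OC[C@@H](O)C[C@@H](O)CC(=O)O`, differs from compound 1 in one place: (3-chlorobenzyl)(methyl)amino in place of benzylamino on a carbonyl carbon. This change combines two features already seen separately. As in compound 2, the amide hydrogen is gone, the only hydrogen-bond donor of the leaving group; as in compound 3, a chlorine sits on the benzyl ring, though at a different carbon. Since both of those single changes gave higher numbers, he expects the combined change to give a large rise as well, so that compound 4 is estimated at 20000 nM in this assay, within 5000 nM to 80000 nM, which means an expected step of a 23-fold higher number from compound 1 to compound 4 (1.36 log units; beyond the scatter).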

Compound 4, half-maximal inhibitory concentration: 2120 nM
The estimate for compound 4 lay 9.4-fold (0.97 log units) above the measured number, and the stated range ends above it.
By their numbers in this assay, from the lowest: compound 1; then compound 4; then compound 3; then compound 2.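

On the carbonyl carbon, an amide without its hydrogen need not lie far from compound 1 in this assay: the change gives a 2.4-fold higher number from compound 1 to compound 4 (0.38 log units; beyond the scatter) as a modest step, and there is also a 15-fold lower number from compound 2 to compound 4 (1.18 log units; beyond the scatter) as a large step between the two amides lacking that hydrogen, so the large rise seen with piperidin-1-yl does not follow from the loss of the hydrogen alone. A chlorine on the benzyl ring does not fix the number either, as a 4.0-fold lower number from compound 3 to compound 4 (0.60 log units; beyond the scatter) shows, although the methyl and the place of the chlorine change together in that step. No measurement given here accounts for these differences.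

The compounds shown leave open how much of the step from compound 1 belongs to the methyl and how much to the chlorine. Benzyl(methyl)amino and (3-chlorobenzyl)amino on the same carbonyl carbon would separate the two.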